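The compounds below may be only part of what the source reports. "The series", "measured", "known", "first", "only" and "open" are said of these compounds alone.

Compound 3 `Cn1c(-c2ccc(Cl)cc2)c(CCC(=O)N2CCC(O)(Cc3ccccc3)CC2)c2cc(Cl)ccc21` gives the lowest number among the three compounds measured in an assay on CHO cells for displacement of a labelled ligand from Substance-P receptor (Homo sapiens); on this read-out lower numbers stand for stronger inhibition and higher numbers for weaker inhibition: compound 3 gives 0.16 nM, whereas compound 1 `COc1ccccc1N1CCN(C(=O)CCc2c(-c3ccc(Cl)cc3)[nH]c3ccccc23)CC1` gives 31 nM and compound 2 `COc1ccccc1N1CCN(C(=O)CCc2c(-c3ccc(Cl)cc3)[nH]c3cc(Cl)cc(Cl)c23)CC1` gives 570 nM, both gaps lying beyond the scatter. Compound 4 `Cn1c(-c2ccc(Cl)cc2)c(CCC(=O)N2CCC(O)(Cc3ccccc3)CC2)c2cc(-n3cccc3)ccc21` differs from compound 3 by 1H-pyrrol-1-yl in place of chloro on an aromatic carbon. For the measured compounds named here, no measured pair shows the effect of this particular exchange, so any expectation rests on compound 3 alone. Because compound 3 gives 0.16 nM in this assay, the starting point is very strong. The expected step is a 2.5-fold higher number from compound 3 to compound 4 (0.40 log units; beyond the scatter), a modest loss or none beyond the scatter. Compound 4 is therefore estimated at 0.4 nM, with a plausible range from 0.08 nM to 2 nM.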

Compound 4, half-maximal inhibitory concentration: 2.3 nM
For compound 4 the middle estimate is 5.8-fold (0.76 log units) below the measured one; the measured number lies above the stated range.
By their numbers in this assay, from the lowest: compound 3; then compound 4; then compound 1; then compound 2.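

In this assay, for the compounds shown here, this carbon of the six-membered aromatic ring proves sensitive to the exchange: 1H-pyrrol-1-yl in place of chloro gives a 14-fold higher number from compound 3 to compound 4 (1.16 log units; beyond the scatter), a large step and the first reading at this position. Even so, compound 4 retains a value of 2.3 nM while carrying a whole five-membered aromatic ring there. Nothing available bears on why the step is this large.

The compounds shown leave open whether the loss follows from adding the ring or from removing chloro. On these data alone, how a methoxy group, an amine or a carboxylic acid would fare at this carbon also remains open.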